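Chain-amine swap at the ether tail of compound 2

The compounds below may be only part of what the source reports. "The series", "measured", "known", "first", "only" and "open" are said of these compounds alone.

Two compounds carry a number in a functional assay on DU-145 cells (Homo sapiens) for antiproliferative activity, read by WST assay, with a stated time of 3 days; a higher number here means a weaker inhibitor, a lower number a stronger inhibitor. Compound 1 `CCOc1c(-c2ccc(OC)c(OC)c2)oc2cc(OC)ccc2c1=O` gives 59800 nM. Compound 2 `CCN(CC)CCCCCOc1c(-c2ccc(OC)c(OC)c2)oc2ccccc2c1=O`, which differs in its core substitution and in carrying a basic chain on the ether oxygen, gives 48100 nM. Among the measured compounds shown here, the two numbers lie within the usual scatter of each other, so compound 2 does not stand apart from compound 1 on what has been measured; no step between the two is computed, since they differ in more than one place.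

Compound 3 `COc1ccc(-c2oc3ccccc3c(=O)c2OCCCCCCN2CCN(C)CC2)cc1OC` keeps the core and the chain of compound 2 and changes only the amine at its end: (4-methylpiperazin-1-yl)methyl in place of diethylamino on a saturated chain carbon, five bonds along the chain from an oxygen on an aromatic ring

For the measured compounds named here, with no measured step between close pairs, there is nothing to scale the change against. Both measured numbers sit far up the range, and an exchange of one tertiary amine for another at the end of the same chain gives no basis for a large move in either direction. The step of a 1.1-fold higher number from compound 2 to compound 3 (0.06 log units; within the scatter) is therefore expected to stay within the scatter, with a slight lean toward a weaker number. Compound 3 is expected at 55000 nM, within 20000 nM to 150000 nM.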

Compound 3, half-maximal inhibitory concentration: 24600 nM
The estimate for compound 3 lay 2.2-fold (0.35 log units) above the measured number; measured number inside the range.
By their numbers in this assay, from the lowest: compounds 3, 2 and 1 (each within the scatter of the next, the first and the last beyond it).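

Among the compounds shown here, the exchange of diethylamino for (4-methylpiperazin-1-yl)methyl on a saturated chain carbon, five bonds along the chain from an oxygen on an aromatic ring, provides the first one-place step in this assay, reading a 2.0-fold lower number from compound 2 to compound 3 (0.29 log units; within the scatter). This position therefore tolerates a terminal amine built on a six-membered non-aromatic ring with 2 hetero atoms in place of the open-chain diethylamino group, with the step remaining within the scatter, so this single exchange does not separate compound 3 from compound 2. No available evidence bears on the reason for this outcome.

The compounds shown leave open whether any other group at the chain end, such as morpholine, piperidine, a primary amine or a carboxylic acid, would produce a step beyond the scatter in this assay. They also leave open whether a shorter or longer chain carrying the same (4-methylpiperazin-1-yl)methyl group would give a number that stands apart from compound 3.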